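Swapping Pentyl for Tert-Butyl on a Shared Core

This account rests on a few compounds, and the source may have more. Where it says the series, first, only, none or still open, it means among the compounds named here.

Three compounds built on one shared core were measured in an assay on FRT-Jurkat cells for inhibition of nuclear factor NF-kappa-B complex (Homo sapiens), read by flow cytometry, with a stated time of 24 h, tested at 10 uM; on this read-out lower numbers stand for less inhibition and higher numbers for more inhibition at the one concentration tested (going by the name of the read-out). Compound 1 `CCCCCc1ccc(Nc2ccc3c(c2)C(=O)N(C2CCC(=O)NC2=O)C3=O)cc1` gives 12% and stands second highest of the three. Compound 2 `O=C1CCC(N2C(=O)c3cccc(Nc4ccccn4)c3C2=O)C(=O)N1` gives 1%, a number below that of compound 1 by more than the usual scatter. Compound 3 `CCCCCc1ccc(Nc2cccc3c2C(=O)N(C2CCC(=O)NC2=O)C3=O)cc1` gives 23%, above compound 1 by the same margin. Compound 4 `CC(C)(C)c1ccc(Nc2ccc3c(c2)C(=O)N(C2CCC(=O)NC2=O)C3=O)cc1`, not yet measured, differs from compound 1 in one place: tert-butyl in place of pentyl on an aromatic carbon. Going by the values given here, no pair of measured compounds differs in just one place, so no measured step guides this change. For compound 4 only a small step is expected, estimated at a number 2 percentage points lower from compound 1 to compound 4 (within the scatter), not beyond the usual scatter. In this assay compound 4 is expected to reach about 10%, within a range from 0% to 24%.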

Compound 4, a percentage reported as inhibition, at one concentration (the size of the read-out at that concentration, not a potency): 17%
The estimate for compound 4 lay 7 percentage points below the measured number; low and high end bracket the measured number.
By their numbers in this assay, from the lowest: compound 2; then compounds 1, 4 and 3 (each within the scatter of the next, the first and the last beyond it).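

In this assay, going by these compounds alone, tert-butyl in place of pentyl gives a number 5 percentage points higher from compound 1 to compound 4 (within the scatter) and this is the first change in a single place on the shared core, on an aromatic carbon para to a large group. At this position the read-out does not tell the branched tert-butyl from the straight pentyl. No measurement that could explain this result is at hand.

Going by these compounds, whether an amine, a carboxylic acid or a longer chain such as octyl at this position would read differently stays open. Also open, on these data alone, is how tert-butyl would read on the core of compound 3.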